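Thiophenyl enone series on DU-145 cells: notes

This account rests on a few compounds, and the source may have more. Where it says the series, first, only, none or still open, it means among the compounds named here.

Compound 1 `Cc1ccc(S/C(=C/c2c(O)cc(O)cc2O)C(=O)c2ccc(Cl)cc2)cc1` and compound 2 `O=C(/C(=C\c1c(O)cc(O)cc1O)Sc1ccccc1Br)c1ccc(Cl)cc1` share one core; compound 3 `O=C(/C(=C\c1ccc(O)c([N+](=O)[O-])c1)Sc1ccccc1Br)c1ccc(Cl)cc1` carries a different core, and the difference between the two cores is not broken down here. In a functional assay on DU-145 cells (Homo sapiens) for inhibition, read by trypan blue exclusion, with a stated time of 96 h (a lower number here means a stronger inhibitor of growth, a higher number a weaker inhibitor of growth), compound 1 gives only a limit, > 100000 nM. In this assay compound 2 likewise gives only a limit, > 100000 nM. In this assay, among the measured compounds shown here, compound 3 gives 25000 nM, the only actual number in the set.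

The change from compound 2 to compound 1 is 4-methylphenyl in place of 2-bromophenyl on a sulfur. Its step, a step that the two limits leave unreadable from compound 2 to compound 1, cannot be sized because both values sit at the same limit, (the limit of > 100000 nM in this assay, at which 2 of the 3 values shown sit). So the effect of this change on growth inhibition is not known from the measured pair.

Compound 4 `Cc1ccc(S/C(=C/c2ccc(O)c([N+](=O)[O-])c2)C(=O)c2ccc(Cl)cc2)cc1` is not yet measured. It differs from compound 3 by 4-methylphenyl in place of 2-bromophenyl on a sulfur, the same change that turns compound 2 into compound 1, on the same kind of position in both cases. Since the earlier step gives no readable size, the expectation for compound 4 rests only on compound 3 at 25000 nM and on the absence of any sign that this change moves the number. The step from compound 3 to compound 4 is estimated as a 1.2-fold higher number from compound 3 to compound 4 (0.08 log units; within the scatter), with wide uncertainty. Compound 4 is therefore expected to give about 30000 nM in this assay, somewhere between 8000 nM and 120000 nM, with a fair chance that only a limit is reported.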

Compound 4, concentration for 50% growth inhibition: 10000 nM
Beside the measured number, compound 4's estimate is 3.0-fold (0.48 log units) above it; measured number inside the range.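

In this assay, on the core of compound 3, 4-methylphenyl in place of 2-bromophenyl on a sulfur gives a 2.5-fold lower number from compound 3 to compound 4 (0.40 log units; beyond the scatter). The same change on the core shared by compound 1 and compound 2 has no readable size, and it cannot be compared with the new step because both of those compounds sit at one limit: the limit of > 100000 nM in this assay, at which 2 of the 4 values shown sit. The change therefore has a sized effect on one core only; the limit pair neither supports nor contradicts its carrying over to the other core, and a single readable pair cannot show how far the step would hold on any further core.

Still open, going by these compounds, is how the number in this assay responds to other groups on the sulfur, such as an unsubstituted phenyl, a 4-bromophenyl, a 2-methylphenyl or a benzyl group, which would help to separate the part played by the bromine from that played by the methyl group. Also open, on these data alone, is whether a ring bearing an amine or a carboxylic acid on the sulfur would give a readable number on the core of compound 1, and whether such a step would match the one seen on the core of compound 3.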